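Hydroxycyclobutyl to methoxycyclohexylmethyl: expected stability loss

The compounds below may be only part of what the source reports. "The series", "measured", "known", "first", "only" and "open" are said of these compounds alone.

In an ADME assay on S9 fraction from liver (Homo sapiens) for metabolic stability, with a stated time of 1 h (on this read-out higher numbers stand for a more stable compound and lower numbers for a less stable compound), compound 1 `N#Cc1cnc(NCc2cnccc2C(F)(F)F)cc1N[C@H]1C[C@H](O)C1` gives 96%, the highest of three measured numbers. Compound 2 `N#Cc1cnc(NCc2cnccc2C(F)(F)F)cc1NC[C@H]1C[C@@H](O)C1` gives 84%, and compound 3 `N#Cc1cnc(NCc2cnccc2C(F)(F)F)cc1NC[C@H]1CC[C@@H](O)CC1` gives 41%. Compound 4 `CO[C@H]1CC[C@@H](CNc2cc(NCc3cnccc3C(F)(F)F)ncc2C#N)CC1` is unmeasured and differs from compound 1 as follows: (4-methoxycyclohexyl)methyl in place of 3-hydroxycyclobutyl on a nitrogen on an aromatic ring. For the measured compounds named here, two measured steps bear on this change: the modest a number 12 percentage points lower from compound 1 to compound 2 (beyond the scatter), and the large a number 55 percentage points lower from compound 1 to compound 3 (beyond the scatter). The second matters most, as (4-hydroxycyclohexyl)methyl is the closest measured group to (4-methoxycyclohexyl)methyl. Going by the values given here, no measured step compares those two groups directly, so the range stays wide. A large downward step is therefore expected, estimated as a number 63 percentage points lower from compound 1 to compound 4 (beyond the scatter). Compound 4 is estimated at 33%, with an expected range of 10% to 55%.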

Compound 4, percent of the compound remaining: 4%
For compound 4 the middle estimate is 29 percentage points above the measured one; the whole stated range lies above it.
By their numbers in this assay, from the lowest: compound 4; then compound 3; then compound 2; then compound 1.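

On the cyclohexylmethyl substituent in this assay, methyl in place of hydrogen on the oxygen gives a number 37 percentage points lower from compound 3 to compound 4 (beyond the scatter) and shows that this single change matters on its own, apart from ring size. The full change at the nitrogen gives a number 92 percentage points lower from compound 1 to compound 4 (beyond the scatter) as the largest step of the set, while the change on the saturated chain carbon gives a number 80 percentage points lower from compound 2 to compound 4 (beyond the scatter) with both ring and oxygen substituent altered. Nothing here gives a cause for these steps. From the compounds shown here alone, whether a methoxy group on the cyclobutyl ring costs as much, and how an ethoxy group or a fluorine on the cyclohexyl ring would read, stays open.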